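The source may report more compounds than this note shows. Statements on the series, on what has been measured and on what is new or still open speak of the compounds shown alone.

Measured so far in an ADME assay on microsomes from liver (Rattus norvegicus) for metabolic stability, read by LC-MS, tested at 0.5 uM; a higher number here means that the compound lasts longer, a lower number that the compound disappears faster:
compound 1, `Cc1nc(C)c([C@H](OC(C)(C)C)C(=O)O)c(N2CCC(C)(C)CC2)c1-c1ccc(OCCc2ccc(F)cc2F)cc1`: > 2 h
compound 2, `Cc1nc(C)c([C@H](OC(C)(C)C)C(=O)O)c(N2CCC(C)(C)CC2)c1-c1ccc(OCCc2cccnc2)cc1`: 0.783 h

The value given for compound 1 is a limit of this assay, not a number. Going by the values given here, compound 2 is therefore the only compound of the pair with a read half-life in this assay, at 0.783 h. Among the compounds with values here, the one step that joins the two is an at least 2.5-fold lower number from compound 1 to compound 2 (0.40 log units; beyond the scatter); since one end sits at the limit of > 2 h in this assay, at which 1 of the 2 values shown sits, its true size is open upward.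

Compound 3, `Cc1ncsc1CCOc1ccc(-c2c(C)nc(C)c([C@H](OC(C)(C)C)C(=O)O)c2N2CCC(C)(C)CC2)cc1`, is not yet measured. It differs from compound 2 in one place: 4-methyl-1,3-thiazol-5-yl in place of pyridin-3-yl on a saturated chain carbon, two bonds along the chain from an oxygen on an aromatic ring. Within the data shown here, no measured step covers this exchange. Among the measured compounds shown here, the only measured step, from compound 1 to compound 2, concerns a different exchange at the same chain position and runs downward; it says nothing direct about a pyridin-3-yl to 4-methyl-1,3-thiazol-5-yl swap. In this assay compound 3 is therefore expected to stay close to compound 2, with no step beyond the scatter: the estimate is 0.8 h, within 0.35 h to 1.8 h. That estimate corresponds to an expected step of a 1.0-fold higher number from compound 2 to compound 3 (0.01 log units; within the scatter).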

Compound 3, half-life: > 2 h
Compound 3: no number, only a limit; the forecaster's own chance of this, stated with the estimate: 10%; middle value at least 2.5-fold (0.39 log units) from the limit.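

In this assay, the exchange of pyridin-3-yl for 4-methyl-1,3-thiazol-5-yl on a saturated chain carbon, two bonds along the chain from an oxygen on an aromatic ring, gives an at least 2.5-fold higher number from compound 2 to compound 3 (0.40 log units; beyond the scatter), so a ring with hetero atoms at this place does not by itself go with the shorter half-life of compound 2. Compound 3 gives > 2 h, which is a limit of the assay and not a number. Among the three groups shown, pyridin-3-yl alone gives a read half-life, while 2,4-difluorophenyl and 4-methyl-1,3-thiazol-5-yl cannot be ordered, and the step between compound 1 and compound 3 cannot be read, as both end at the same limit: the limit of > 2 h in this assay, at which 2 of the 3 values shown sit.

From the compounds shown here alone, how far compound 1 and compound 3 lie past that limit remains open, and so does any ranking of their two groups. Also open, going by these compounds, is whether the 4-methyl group or the 1,3-thiazole ring carries the change, which an unsubstituted 1,3-thiazol-5-yl would separate, and whether a pyridin-4-yl or a plain phenyl at the same place would stay with compound 2 or with compound 3.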